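A few compounds are considered here, and "the series" means these few. Any claim that something is new, unique, unknown or untested is made for them only; others in the source may bear on it.

Among the measured compounds shown here, in a functional assay on MCF7 cells (Homo sapiens) for inhibition, read by MTT assay, with a stated time of 72 h (on this read-out lower numbers stand for stronger inhibition and higher numbers for weaker inhibition), compound 1 (`CO[C@@H]1[C@H]2OC(=O)C[C@H]2O[C@@H]1[C@@H](O)c1ccccc1`) gives 12700 nM and so holds the higher of the two numbers so far. Compound 2 (`CO[C@@H]1[C@H]2OC(=O)C[C@H]2O[C@@H]1C(=O)c1ccccc1`) gives 3440 nM and lies lower by a gap beyond the usual scatter of repeat measurements.

Compound 3 (`CO[C@@H]1[C@H]2OC(=O)C[C@H]2O[C@@H]1[C@H](O)c1ccccc1`) has not yet been measured. It has the same atoms and bonds as compound 1 and differs only in configuration as drawn, that is, in the three-dimensional arrangement at a single carbon (the two compounds have the same atoms and bonds and differ only in configuration as drawn: 1 of 5 stereo elements differ; a stereocentre at a saturated chain carbon is drawn S in compound 1 and R in compound 3), where a stereocentre at a saturated chain carbon is drawn S in compound 1 and R in compound 3.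

For the measured compounds named here, no measured pair here shows what such a change does, so any expectation is loose. In this assay a small step is expected, no larger than the scatter, with a slight lean toward a lower number. Going by the values given here, that lean rests only on compound 2 standing at 3440 nM as the one other value.

The expected value for compound 3 is 7000 nM with an estimated range from 2000 nM to 25000 nM in this read-out. That estimate amounts to a 1.8-fold lower number from compound 1 to compound 3 (0.26 log units; within the scatter) as the expected step, and the wide range leaves room for a larger move either way.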

Compound 3, half-maximal inhibitory concentration: 4040 nM
The estimate for compound 3 lay 1.7-fold (0.24 log units) above the measured number; the measured number falls inside the stated range.
By their numbers in this assay, from the lowest: compounds 2 and 3 (each within the scatter of the next); then compound 1.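

Turning a single stereocentre at a saturated chain carbon from S to R in this assay gives a 3.1-fold lower number from compound 1 to compound 3 (0.50 log units; beyond the scatter), so this position responds to its three-dimensional arrangement alone, with no atom gained or lost. Compounds 1 and 2 had shown only a gap between two structures with different bonds at this carbon, whereas here the change in the number can be traced to a single source: the fact that compounds 1 and 3 differ only in the configuration as drawn. Compound 3 at 4040 nM and compound 2 at 3440 nM lie within the usual scatter of each other, so among these three compounds only compound 1, with its S arrangement, stands apart.

As far as these compounds go, the other stereocentres keep one arrangement in all three compounds, so what inverting any of them would do to the number in this assay remains open. From the compounds shown here alone, it is also open whether an amine at this same carbon would keep the difference between the S and R forms, and whether that difference holds in any cell line other than this one.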